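Sulfamoyl for ethyl on the chain of compound 2

This account rests on a few compounds, and the source may have more. Where it says the series, first, only, none or still open, it means among the compounds named here.

Of the compounds shown here, two have been measured in a functional assay on the whole organism with Rattus norvegicus as the target; on this read-out lower numbers stand for an effect already at smaller amounts and higher numbers for an effect only at larger amounts of compound. Compound 1 `CC(C)(C)Cc1ccc2nc(N)sc2c1` reaches only a limit of the assay, with > 10 mg/kg (the limit of > 10 mg/kg in this assay, at which 1 of the 2 values shown sits). Going by the values given here, compound 2 `CCCCn1c(=N)sc2cc(OC(F)(F)F)ccc21` gives 10 mg/kg and is the only compound with a number on this read-out. Compound 3 `N=c1sc2cc(OC(F)(F)F)ccc2n1CCS(N)(=O)=O` has not been measured. It differs from compound 2 by sulfamoyl in place of ethyl on a saturated chain carbon, two bonds along the chain from an aromatic nitrogen. Among the compounds with values here, no measured step of this kind exists, so no shift beyond the usual scatter is assumed in either direction: the step of no change at the digits printed from compound 2 to compound 3 (within the scatter) is an expectation only. Compound 3 is estimated at 10 mg/kg, within 3 mg/kg to 30 mg/kg.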

Compound 3, dose for half-maximal effect: 6 mg/kg
Compound 3: the middle estimate sits 1.7-fold (0.22 log units) above what was measured; measured number inside the range.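

In this assay sulfamoyl in place of ethyl on a saturated chain carbon, two bonds along the chain from an aromatic nitrogen, gives a 1.7-fold lower number from compound 2 to compound 3 (0.22 log units; within the scatter) so this position accepts a group with hydrogen-bond donor and acceptors where ethyl has none. The earlier compounds shown here offered no step at this chain, and this first one leaves the read-out within the scatter. Nothing measured here speaks to a cause of this result.

From the compounds shown here alone, whether an amine, a carboxylic acid or a longer chain at the same place would also keep the read-out stays open. So does whether any group on this chain can move it beyond the scatter.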